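This account rests on a few compounds, and the source may have more. Where it says the series, first, only, none or still open, it means among the compounds named here.

Measured compounds in the series:

- compound 1, `COc1ccc(NC(=O)C(=O)c2cn(CC(C)C)c3ccccc23)cn1`: 317 nM
- compound 2, `COCCn1cc(C(=O)C(=O)Nc2ccncc2)c2ccccc21`: > 10000 nM
- compound 3, `COCCc1cc(C(=O)C(=O)Nc2ccc(OC)nc2)c2ccccn12`: 36 nM

In a functional assay on FaDu cells (Homo sapiens) for cytotoxicity, read by MTT assay, with a stated time of 72 h (a higher number here means that more compound is tolerated, a lower number that less compound is tolerated), compound 1 gives 317 nM, the highest of the two numbers recorded in this series. Compound 3 gives 36 nM in this assay, a lower number, and the gap to compound 1 lies beyond the scatter. For compound 2 only a limit is recorded in this assay, > 10000 nM; this is the limit of the assay and not a number, as noted in the limit of > 10000 nM in this assay, at which 1 of the 3 values shown sits.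

The next compound is compound 4, `CCC(C)n1cc(C(=O)C(=O)Nc2ccc(OC)nc2)c2ccccc21`. It differs from compound 1 in one place: sec-butyl in place of isobutyl on an aromatic nitrogen. Among the measured compounds shown here, both groups are four-carbon chains without donors or acceptors, and no measured pair shows such a swap, so no size or direction of step can be read from the data.

For compound 4 the number in this assay is expected to stay close to that of compound 1, with a step from compound 1 to compound 4 of a 1.1-fold higher number from compound 1 to compound 4 (0.04 log units; within the scatter), within the scatter. The estimate for compound 4 is 350 nM, ranging from 120 nM to 1000 nM.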

Compound 4, concentration lethal to 50% of the cells: 68 nM
Beside the measured number, compound 4's estimate is 5.1-fold (0.71 log units) above it; measured number outside the range, below it.
By their numbers in this assay, from the lowest: compounds 3 and 4 (each within the scatter of the next); then compound 1. At a limit, above all of these: compound 2.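

In this assay the swap of isobutyl for sec-butyl on the aromatic nitrogen gives a 4.7-fold lower number from compound 1 to compound 4 (0.67 log units; beyond the scatter) with no atom gained or lost. Among the compounds shown here, this is the first single-place change, and it shows that this position responds to how a four-carbon chain is joined, even with the same counts of hydrogen-bond donors and acceptors. No recorded measurement bears on the cause of this step.

From the compounds shown here alone, whether a shorter ethyl group, a cyclopropyl ring, a longer chain or a chain ending in an amine on this nitrogen would move the number further in either direction remains open. Also open, going by these compounds, is whether the same swap would give a similar step with a different group on the amide nitrogen.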